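Swapping the N-aryl group on a pyrazolone anticancer series

A few compounds are considered here, and "the series" means these few. Any claim that something is new, unique, unknown or untested is made for them only; others in the source may bear on it.

Of the compounds shown here, three have been tested in a functional assay on A549 cells (Homo sapiens) for cytotoxicity, read by MTT assay, with a stated time of 72 h; on this read-out higher numbers stand for weaker inhibition and lower numbers for stronger inhibition. Compound 1, with the structure `Cc1cc(=O)n(-c2cccc(F)c2)nc1C(=O)Nc1ccc(Oc2ncnc3ccsc23)c(F)c1`, gives 5220 nM. Compound 2, with the structure `Cc1cc(=O)n(-c2cccc(F)c2)nc1C(=O)Nc1ccc(Oc2ncnc3sccc23)cc1`, gives 16400 nM. Compound 3, with the structure `Cc1cc(=O)n(-c2ccc(Br)cc2F)nc1C(=O)Nc1ccc(Oc2ncnc3sccc23)c(F)c1`, gives 11500 nM. Among these three numbers compound 3 stands second highest; its value sits within the usual scatter of the value of compound 2, while the value of compound 1 lies beyond the scatter, a clearly lower number.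

Compound 4, with the structure `Cc1cc(=O)n(-c2cccc(F)c2)nc1C(=O)Nc1ccc(Oc2ncnc3sccc23)c(F)c1`, has not yet been measured in this assay. It differs from compound 3 in a single place: 3-fluorophenyl in place of 4-bromo-2-fluorophenyl on an aromatic nitrogen. Compound 2 carries the same 3-fluorophenyl group on the shared core, and compound 3 carries the group that leaves, and their two values lie within the scatter of each other. Going by the values given here, that is the only guide available here, and it gives no reason to foresee a change beyond the scatter in either direction.

Compound 4 is therefore expected to give about 9500 nM in this assay, within a range from 3500 nM to 25000 nM. The step expected from this estimate, a 1.2-fold lower number from compound 3 to compound 4 (0.08 log units; within the scatter), is a small one that would not stand out from repeated measurement.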

Compound 4, half-maximal inhibitory concentration: 19500 nM
The estimate for compound 4 lay 2.1-fold (0.31 log units) below the measured number, within the range that was stated.
By their numbers in this assay, from the lowest: compound 1; then compounds 3, 2 and 4 (each within the scatter of the next).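

In this assay, the first direct test at this position, 3-fluorophenyl in place of 4-bromo-2-fluorophenyl on the aromatic nitrogen gives a 1.7-fold higher number from compound 3 to compound 4 (0.23 log units; within the scatter), so this exchange of aryl groups does not move the number beyond the scatter. Fluoro in place of hydrogen on an aromatic carbon, with a 1.2-fold higher number from compound 2 to compound 4 (0.08 log units; within the scatter), also stays within the scatter, while exchanging one group of 9 heavy atoms on the oxygen for another with the same atom counts gives a 3.7-fold higher number from compound 1 to compound 4 (0.57 log units; beyond the scatter), the only one of these three steps that lies beyond it. Nothing available here accounts for that difference in the size of the steps.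

Going by these compounds alone, the nitrogen has been compared with only two halogen-bearing phenyl groups, so it remains open whether an unsubstituted phenyl, a pyridyl ring or a phenyl carrying a methoxy group or an amine would change the number beyond the scatter. Going by these compounds, it is also open whether the same exchange on the nitrogen would give a similar step on the core of compound 1, whose group on the oxygen differs.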